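Lengthening the sulfonyl chain from compound 2 to compound 3

The compounds below may be only part of what the source reports. "The series", "measured", "known", "first", "only" and "open" are said of these compounds alone.

Measured in a functional assay on HEK293 cells (Homo sapiens) for inhibition; a lower number here means a stronger inhibitor, a higher number a weaker inhibitor:
- compound 1 `CCCCCCCCS(=O)(=O)NCCCNCCCNCCCCNCCCN`: 816 nM
- compound 2 `CCCCCCCCCCCCCCCCS(=O)(=O)NCCCNCCCNCCCCNCCCN`: 200 nM

Of the two measured compounds, compound 2 has the lower number at 200 nM, making it the stronger inhibitor. Compound 3 `CCCCCCCCCCCCCCCCCCS(=O)(=O)NCCCNCCCNCCCCNCCCN` is not yet measured. Its structure differs from that of compound 2 by one change: ethyl in place of hydrogen on a saturated chain carbon, ten or more bonds along the chain from a sulfonyl sulfur. Within the data shown here, only one measured step bears on this change, and it is a modest one: a 4.1-fold lower number from compound 1 to compound 2 (0.61 log units; beyond the scatter). That step added octyl in place of hydrogen on the same chain, whereas ethyl is the smaller addition here. Two measured compounds cannot show whether the direction continues at greater chain length. A small further fall in this assay is therefore expected, possibly none beyond the scatter. The expected step is a 1.3-fold lower number from compound 2 to compound 3 (0.12 log units; within the scatter). Compound 3 is estimated at 150 nM, with an expected range of 70 nM to 320 nM.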

Compound 3, half-maximal inhibitory concentration: 1060 nM
Compound 3: the middle estimate sits 7.1-fold (0.85 log units) below what was measured; measured number outside the range, above it.
By their numbers in this assay, from the lowest: compound 2; then compounds 1 and 3 (each within the scatter of the next).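

In this assay the trend on this chain changes direction: ethyl in place of hydrogen gives a 5.3-fold higher number from compound 2 to compound 3 (0.72 log units; beyond the scatter) and so reverses the earlier fall. Decyl in place of hydrogen, eight bonds along the chain from a sulfonyl sulfur, gives a 1.3-fold higher number from compound 1 to compound 3 (0.11 log units; within the scatter) overall, so among these three compounds only compound 2 stands apart from the other two. No evidence here bears on the cause of this reversal.

Three chain lengths leave open how sharp the turn is and whether the best length lies at the chain of compound 2 or close to it on either side. Also open, going by these compounds, is whether a chain ending in a carboxylic acid would keep the number of compound 2 in this series.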